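Rearranging the carbons on the amine of compound 2

The source may report more compounds than this note shows. Statements on the series, on what has been measured and on what is new or still open speak of the compounds shown alone.

In a functional assay on HCT-8 cells (Homo sapiens) for antiproliferative activity, read by MTT assay, with a stated time of 48 h (on this read-out higher numbers stand for weaker inhibition and lower numbers for stronger inhibition), compound 1 `C=C(c1cc(OC)c(OC)c(OC)c1)c1ccc(OC)cc1NC(=O)CN` gives 60 nM and compound 2 `C=C(c1cc(OC)c(OC)c(OC)c1)c1ccc(OC)cc1NC(=O)CNCC` gives 590 nM, the higher of the two numbers and therefore the weaker inhibition. The next molecule, compound 3 `C=C(c1cc(OC)c(OC)c(OC)c1)c1ccc(OC)cc1NC(=O)CN(C)C`, has the same atoms as compound 2, joined differently: dimethylamino in place of ethylamino on a saturated chain carbon bound to a carbonyl carbon. In words, dimethylamino stands in place of ethylamino on a saturated chain carbon bound to a carbonyl carbon.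

Within the data shown here, only one measured step bears on this change: ethyl in place of hydrogen on an amine nitrogen, a 9.8-fold higher number from compound 1 to compound 2 (0.99 log units; beyond the scatter). That step is modest but beyond the scatter, and it shows that a change on this nitrogen can move the number. Among the measured compounds shown here, it does not test dimethylamino, since no measured compound carries that group. Compound 3 keeps the atoms of compound 2 and does not return to the unsubstituted amine of compound 1, so its number is expected to stay near that of compound 2. The expected change in this assay is small, within the scatter and leaning slightly lower: a 1.4-fold lower number from compound 2 to compound 3 (0.15 log units; within the scatter). For compound 3 the estimated value is 420 nM, with an expected range of 130 nM to 1300 nM.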

Compound 3, half-maximal inhibitory concentration: 340 nM
The estimate for compound 3 lay 1.2-fold (0.09 log units) above the measured number; the range from low to high includes it.
By their numbers in this assay, from the lowest: compound 1; then compounds 3 and 2 (each within the scatter of the next).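

The new step tests something the first pair could not: whether the arrangement of the carbons on this nitrogen matters, or only their presence. In this assay, replacing ethylamino with dimethylamino on a saturated chain carbon bound to a carbonyl carbon gives a 1.7-fold lower number from compound 2 to compound 3 (0.24 log units; within the scatter) and so leaves compound 2 and compound 3 indistinguishable, even though ethylamino has 1 hydrogen-bond donor and dimethylamino has 0 hydrogen-bond donors. Compound 3 also gives a 5.7-fold higher number from compound 1 to compound 3 (0.75 log units; beyond the scatter) and thus joins compound 2 on the far side of the scatter from compound 1, which keeps the plain amino group and remains the strongest inhibitor of the three. Nothing available here explains why either carbon-bearing amine differs from the plain amino group.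

Methylamino, with a single methyl on this nitrogen, would show whether one carbon is enough to produce the gap from compound 1 or whether the number sits somewhere in between. Diethylamino, a longer chain such as propylamino, or a ring amine such as pyrrolidinyl would show whether adding more carbons here moves the number any further.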